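Bromo benzanilides against thiosulfate sulfurtransferase

The source may report more compounds than this note shows. Statements on the series, on what has been measured and on what is new or still open speak of the compounds shown alone.

Measured so far:
compound 1 `COc1c(Br)cccc1C(=O)Nc1ccccc1`: > 100000 nM
compound 2 `O=C(Nc1cccc(Cl)c1)c1cccc(Br)c1`: > 100000 nM
compound 3 `COc1c(Br)cc(Br)cc1C(=O)Nc1cccc(Cl)c1`: > 100000 nM

In an assay on isolated protein for inhibition of thiosulfate sulfurtransferase (Homo sapiens), with a stated time of 60 min, in the absence of a further agent (on this read-out higher numbers stand for weaker inhibition and lower numbers for stronger inhibition), compound 1 gives > 100000 nM, which is a limit of the assay and not a number. Compound 2 gives > 100000 nM, again a limit. Compound 3 gives > 100000 nM, also a limit. Compound 3 therefore stands at the limit of > 100000 nM in this assay, at which 3 of the 3 values shown sit, with no number to set it apart from the other two. For the measured compounds named here, no step between measured compounds is known. Compound 4 `COc1c(Br)cccc1C(=O)Nc1cccc(Cl)c1` differs from compound 3 by hydrogen in place of bromo on an aromatic carbon. Going by the values given here, since every value so far is a limit, no step beyond the scatter is expected from compound 3 to compound 4, and a limit is again the likely outcome. Compound 4 is estimated at 150000 nM (range 50000 nM to 500000 nM), an expected step that the limit leaves unreadable from compound 3 to compound 4.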

Compound 4, half-maximal inhibitory concentration: > 100000 nM
Compound 4 was reported as a limit; the forecaster's own chance of this, stated with the estimate: 85%; the middle value is on the limit's open side.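

No step can be read from compound 4 to compound 1, compound 2 or compound 3, because all four values are limits: the limit of > 100000 nM in this assay, at which 4 of the 4 values shown sit.

The compounds shown leave open which change to the shared core, if any, would give a readable value.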